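The source may hold more compounds than are shown below. What is called first, only, known or untested is meant among the compounds shown, and "the series" means these compounds.

Of the compounds shown here, two that share one core have been tested so far in a functional assay on CCRF-CEM cells (Homo sapiens) for inhibition, read by sulforhodamine B assay, with a stated time of 48 h, tested at 10 uM; on this read-out higher numbers stand for more inhibition of growth at the one concentration tested and lower numbers for less inhibition of growth. Compound 1 (`CC(=O)c1ccc(NC(=O)Cn2nc(-c3ccc(Cl)cc3)nc2N)cc1`) gives 19.9% and compound 2 (`C/C(=N/O)c1ccc(NC(=O)Cn2nc(C(F)(F)F)nc2N)cc1`) gives 10.5% and these two values lie within the usual scatter of each other. The two compounds differ in more than one place, so their values cannot be tied to any single structural feature. The next compound to be measured is compound 3 (`CC(=O)c1ccc(NC(=O)Cn2nc(C(F)(F)F)nc2N)cc1`), which keeps the trifluoromethyl of compound 2 and changes one group only. The change is a group of 3 heavy atoms (2 carbon, 1 oxygen; no ring) in place of a group of 4 heavy atoms (2 carbon, 1 nitrogen, 1 oxygen; no ring), on an aromatic carbon and the group that enters is acetyl, para to a large group. Within the data shown here, no measured pair isolates this change, so the expectation rests on little. Compound 1, which also carries the acetyl, reads 19.9% and so gives no sign of a large gain, although it differs from compound 3 elsewhere. The expected a number 3.5 percentage points higher from compound 2 to compound 3 (within the scatter) is small and is not estimated to go beyond the scatter. For compound 3 the estimated value is 14% (expected range 3% to 28%).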

Compound 3, percent growth inhibition at one concentration: 6.78%
Estimate against measurement, compound 3: 7.2 percentage points above; the measured number falls inside the stated range.
By their numbers in this assay, from the lowest: compounds 3, 2 and 1 (each within the scatter of the next, the first and the last beyond it).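

In this assay, the acetyl in place of a group of 4 heavy atoms, on an aromatic carbon para to a large group, gives a shift that stays within the scatter (a number 3.7 percentage points lower from compound 2 to compound 3 (within the scatter)). Among these compounds, with trifluoromethyl kept on the shared core, this place therefore shows no measurable difference between these two groups, which the earlier compounds could not show because they differed in more than one place. Among the compounds shown here, the other place gives the only single-change step here that goes beyond the scatter: with acetyl kept, trifluoromethyl in place of 4-chlorophenyl gives a number 13.1 percentage points lower from compound 1 to compound 3 (beyond the scatter), a modest step for which nothing measured here offers an explanation.

As far as these compounds go, what remains open is whether other groups at the acetyl place, such as an amine or a carboxylic acid, would also stay within the scatter of compound 3. From the compounds shown here alone, it is also open whether the step at the other place follows the size of the entering group, which could be tested with a methyl or an unsubstituted phenyl, and whether the group of 4 heavy atoms would read like acetyl with 4-chlorophenyl present.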